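The source may hold more compounds than are shown below. What is called first, only, known or untested is meant among the compounds shown, and "the series" means these compounds.

Working notes on the series.

Of the compounds shown here, two carry a number so far. Compound 1, `O=C(O)CCCc1ccc(NCc2ccc(-c3ccccc3)cc2)cc1`, gives 1580 nM in a functional assay for agonist activity at Free fatty acid receptor 1 (Homo sapiens); on this read-out higher numbers stand for an effect only at larger amounts of compound and lower numbers for an effect already at smaller amounts. Compound 2, `Cc1ccc(CNc2ccc(CCC(=O)O)cc2)cc1`, gives 3980 nM in this assay; this is the higher of the two numbers, and the gap to compound 1 lies beyond the usual scatter of the assay, so compound 2 stands as the one that needs the larger amount of the two.

The next compound, compound 3, `COc1ccc(CNc2ccc(CCC(=O)O)cc2)cc1`, is not yet measured. It differs from compound 2 in one place: methoxy in place of methyl on an aromatic carbon. For the measured compounds named here, no step between two measured compounds shows what such a change does here; the only pair with numbers, compound 1 and compound 2, differs in several places at once and gives no guide to this exchange.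

With nothing in the series to point either way, the expectation for compound 3 is a step from compound 2 of about a 1.1-fold lower number from compound 2 to compound 3 (0.06 log units; within the scatter), that is, none beyond the scatter. The estimated value for compound 3 in this assay is 3500 nM, with a range of 1200 nM to 10000 nM.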

Compound 3, half-maximal effective concentration: 1260 nM
The estimate for compound 3 lay 2.8-fold (0.44 log units) above the measured number; low and high end bracket the measured number.
By their numbers in this assay, from the lowest: compounds 3 and 1 (each within the scatter of the next); then compound 2.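

For the compounds shown here, this is the first step that isolates a single change, and it shows that the aromatic carbon para to a large group is not indifferent to what it carries. In this assay, methoxy in place of methyl gives a 3.2-fold lower number from compound 2 to compound 3 (0.50 log units; beyond the scatter), so on this one pair the larger group, with its added oxygen and its hydrogen-bond acceptor, goes with an effect at smaller amounts of compound. The change alters the heavy-atom count and the acceptor count together, so this single step cannot assign the shift to either one, and no measurement at hand bears on its origin.

The compounds shown leave open how other groups would read at this same place, such as ethoxy, a chlorine atom, a dimethylamino group or a plain hydrogen, and so whether the step belongs to methoxy alone or forms part of a wider trend. They also leave open whether methoxy in place of methyl would give a similar step on a compound with a longer chain carrying the carboxylic acid.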